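Removing One Hydroxy Group from Compound 2

The source may report more compounds than this note shows. Statements on the series, on what has been measured and on what is new or still open speak of the compounds shown alone.

Compound 1 `O=C(CCc1nc2ccccc2c(=O)[nH]1)N/N=C/c1ccc(O)c(O)c1`: 255000000 nM
Compound 2 `O=C(CCCc1nc2ccccc2c(=O)[nH]1)N/N=C/c1cc(O)c(O)c(O)c1`: 183000000 nM

Both compounds were tested in a functional assay on cells (Erythrocyte, Homo sapiens) for inhibition, read by spectrophotometry and hemolysis, with a stated time of 10 min; a lower number here means a stronger inhibitor, a higher number a weaker inhibitor. For the measured compounds named here, compound 2, at 183000000 nM, lies within the scatter of compound 1, the only other compound measured so far. These two compounds differ in more than one place, so neither value isolates the effect of a single structural change.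

The next compound, compound 3 `O=C(CCCc1nc2ccccc2c(=O)[nH]1)N/N=C/c1ccc(O)c(O)c1`, goes from 3,4,5-trihydroxyphenyl in compound 2 to 3,4-dihydroxyphenyl. It has hydrogen in place of hydroxy on an aromatic carbon. Going by the values given here, no measured pair shows this change directly. Compound 1 also carries 3,4-dihydroxyphenyl, on a different chain, and gives 255000000 nM, which is within the scatter of compound 2. On that limited evidence, no step beyond the scatter is expected in this assay, and no clear direction can be assigned. The estimated step is a 1.2-fold higher number from compound 2 to compound 3 (0.07 log units; within the scatter). For compound 3 the estimated value is 215000000 nM, with an expected range of 120000000 nM to 380000000 nM.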

Compound 3, half-maximal inhibitory concentration in the Erythrocyte assay: 300000000 nM
Compound 3: the middle estimate sits 1.4-fold (0.14 log units) below what was measured; the measured number falls inside the stated range.
By their numbers in the Erythrocyte assay, from the lowest: compounds 2, 1 and 3 (each within the scatter of the next).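

For the compounds shown here, with the chain and the shared core held the same, in the Erythrocyte assay compound 2 gives 183000000 nM and compound 3 gives 300000000 nM, so hydrogen in place of hydroxy on this aromatic carbon gives a 1.6-fold higher number from compound 2 to compound 3 (0.21 log units; within the scatter) as the first direct reading of this change, where the earlier comparison rested on two compounds that also differed in their chains. In a physicochemical assay, read by spectrophotometry, with a stated time of 15 min (on this read-out lower numbers stand for stronger inhibition and higher numbers for weaker inhibition), compound 2 gives 45000000 nM and compound 3 gives 75000000 nM, so the same change gives a 1.7-fold higher number from compound 2 to compound 3 (0.22 log units; within the scatter). Both steps stay inside the usual variation, which means that neither the Erythrocyte assay nor the physicochemical assay shows a measurable effect of taking this hydroxy group away from 3,4,5-trihydroxyphenyl. No supporting measurement is available that could explain this result.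

The compounds shown leave open whether a different group on this aromatic carbon, such as a methoxy group, an amine or a fluorine atom, would give a step beyond the scatter, since hydrogen is the only replacement seen here. They also leave open what removing a further hydroxy group from 3,4-dihydroxyphenyl would do, and whether a longer chain would change the picture.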